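A 3,5-dimethoxyphenyl swap at the assay limit

The source may hold more compounds than are shown below. What is called first, only, known or untested is meant among the compounds shown, and "the series" means these compounds.

Compound 1 `Cc1ccc(S(=O)(=O)N[C@@H](CC(=O)NC(C)(C)C)C(=O)NCCNC(=O)Nc2ccccc2)cc1` and compound 2 `Cc1ccc(S(=O)(=O)N[C@@H](CC(=O)NC(C)(C)C)C(=O)NCCNC(=O)c2ccccc2F)cc1` share one core and differ on a carbonyl carbon. In an ADME assay on HepG2 cells (Homo sapiens) for cytotoxicity (a higher number here means that more compound is needed for the effect, a lower number that less compound is needed), compound 1 gives > 11000 nM as a limit of the assay, not a number. In this assay, among the measured compounds shown here, compound 2 gives > 11000 nM as a limit too, so it stands where the only other value stands. For the measured compounds named here, the one measured step that the two limits leave unreadable from compound 1 to compound 2 has no readable size, and the evidence amounts to the limit of > 11000 nM in this assay, at which 2 of the 2 values shown sit, and nothing sharper. Compound 3 `COc1cc(OC)cc(C(=O)NCCNC(=O)[C@H](CC(=O)NC(C)(C)C)NS(=O)(=O)c2ccc(C)cc2)c1` keeps the core and brings 3,5-dimethoxyphenyl in place of 2-fluorophenyl on a carbonyl carbon, with the counted difference 3,5-dimethoxyphenyl in place of 2-fluorophenyl on a carbonyl carbon as its whole change. No measured step sizes this change, so no step beyond the scatter is expected. In this assay the estimated step is a step that the limit leaves unreadable from compound 2 to compound 3 for this pair, and another limit is the likely report. For compound 3 the estimated value is 14000 nM with 8000 nM to 40000 nM as its expected range.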

Compound 3, half-maximal effective concentration: > 11000 nM
Compound 3: only a limit was reported; the forecaster's own chance of this, stated with the estimate: 85%; the middle value lies beyond the limit too.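

In this assay compound 3 gives > 11000 nM, a limit of the assay and not a number. Its steps from compound 1 and compound 2 therefore cannot be read. The compounds shown leave open how much of each compound the effect requires, and whether changes on the carbonyl carbon alter that amount.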